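Ring substituent rearrangement in the urea series

The source may report more compounds than this note shows. Statements on the series, on what has been measured and on what is new or still open speak of the compounds shown alone.

Compound 2 `CSc1cc(C)nc(Cl)c1NC(=O)N(Cc1ccc(Oc2ccc(F)cc2)cc1)C1CCCCCC1` stands highest of the two numbers measured in an assay for inhibition of acyl-CoA:cholesterol acyltransferase (Oryctolagus cuniculus), using microsomes (on this read-out lower numbers stand for stronger inhibition and higher numbers for weaker inhibition), where compound 2 gives 46 nM. Its nearest neighbour is compound 1 `COc1cc(C)nc(OC)c1NC(=O)N(Cc1ccc(Oc2ccc(F)cc2)cc1)C1CCCCCC1`, which in this assay gives 33 nM; the step of a 1.4-fold higher number from compound 1 to compound 2 (0.14 log units; within the scatter) lies within the scatter. Compound 3 `CSc1nc(C)cc(Cl)c1NC(=O)N(Cc1ccc(Oc2ccc(F)cc2)cc1)C1CCCCCC1` is not yet measured. It differs from compound 2 by a group of 10 heavy atoms (7 carbon, 1 nitrogen, 1 sulfur, 1 chlorine; one six-membered aromatic ring with 1 hetero atom) in place of a group of 10 heavy atoms (7 carbon, 1 nitrogen, 1 sulfur, 1 chlorine; one six-membered aromatic ring with 1 hetero atom), on an amide-type nitrogen; the two structures hold the same atoms, joined differently. Within the data shown here, no measured step touches this change directly. Among the measured compounds shown here, the only step so far, a 1.4-fold higher number from compound 1 to compound 2 (0.14 log units; within the scatter), replaced the whole ring group and stayed within the scatter, which gives no ground to expect a shift beyond the scatter here. A step of no change at the digits printed from compound 2 to compound 3 (within the scatter) is therefore expected, with no direction favoured. Compound 3 is estimated at 46 nM in this assay, within a range of 15 nM to 140 nM.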

Compound 3, half-maximal inhibitory concentration: 12 nM
Compound 3: middle estimate off by 3.8-fold (0.58 log units), on the high side; measured number below the stated range.
By their numbers in this assay, from the lowest: compound 3; then compounds 1 and 2 (each within the scatter of the next).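

Working notes: the ring group on the amide-type nitrogen responds to how its atoms are joined, not only to which atoms it holds. In this assay, among these compounds, with the atoms unchanged, the rearrangement gives a 3.8-fold lower number from compound 2 to compound 3 (0.58 log units; beyond the scatter) and lies beyond the scatter, whereas the only earlier step, between two different ring groups, stayed within it. The rearranged group also separates from the group of compound 1, with a 2.8-fold lower number from compound 1 to compound 3 (0.44 log units; beyond the scatter), so compound 3 now holds the lowest number of the three, beyond the scatter of both others.

No measurement at hand bears on the reason for this difference. Also open, on these data alone, is whether the same sensitivity holds when an amine or a carboxylic acid is carried on this ring group, or whether a longer chain in place of the methylsulfanyl group keeps the number of compound 3.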